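Methoxy in Place of Chloro, Made Twice

The source may hold more compounds than are shown below. What is called first, only, known or untested is meant among the compounds shown, and "the series" means these compounds.

Measured compounds:
compound 1 `Cc1cc2cc(NS(=O)(=O)c3cc(C(=O)NO)ccc3Cl)ccc2n(C)c1=O` — 13%
compound 2 `COc1ccc(C(=O)NO)cc1S(=O)(=O)Nc1ccc2c(c1)cc(C)c(=O)n2C` — 21%
compound 3 `Cc1cc2cc(NCc3cc(C(=O)NO)ccc3Cl)ccc2n(C)c1=O` — 28%

All three compounds were tested in an assay on isolated protein for inhibition of protein deacetylase HDAC6 (Homo sapiens), read by fluorescence, with a stated time of 90 min, tested at 1 uM; a lower number here means a weaker effect, a higher number a stronger effect of the compound at the concentration tested. Compound 1 gives 13% in this assay, compound 2 gives 21%, and compound 3 gives 28%. Compound 1 and compound 2 differ in one place only: methoxy in place of chloro on an aromatic carbon. The step that this change made is a number 8 percentage points higher from compound 1 to compound 2 (within the scatter), so the two values cannot be told apart with confidence. Compound 3 stands highest of the three numbers; the gap to compound 2 lies within the scatter, while the gap to compound 1 lies beyond it. How the core of compound 3 differs from the core of compound 1 is not broken down here.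

Compound 4 `COc1ccc(C(=O)NO)cc1CNc1ccc2c(c1)cc(C)c(=O)n2C` has not yet been measured. It differs from compound 3 by methoxy in place of chloro on an aromatic carbon, which is the same change, at the same place, as that from compound 1 to compound 2. Because that earlier step was a number 8 percentage points higher from compound 1 to compound 2 (within the scatter), compound 4 is expected to sit close to compound 3, with an estimated step of a number 5 percentage points higher from compound 3 to compound 4 (within the scatter). The estimate rests on one pair only, so it is held loosely. Compound 4 is estimated at 33% in this assay, with a range from 18% to 48%.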

Compound 4, a percentage reported as inhibition, at one concentration (the size of the read-out at that concentration, not a potency): 40%
Beside the measured number, compound 4's estimate is 7 percentage points below it; measured number inside the range.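

In this assay, the swap of chloro for methoxy on the second core, para to a hydroxycarbamoyl group, gave a number 12 percentage points higher from compound 3 to compound 4 (beyond the scatter), so the change carried over in the same direction. Going by these compounds alone, only this second step lies clear of the usual scatter, and the series shows just two cores, so nothing here says how the change would behave on any further core, or why it moves the read-out at all; a single concentration also gives the size of the effect and not a potency. Set side by side, the two steps cannot be told apart, which means the change can be treated as carrying over between these two cores without a measurable dependence on which one it sits on: the same change on two cores in this assay, a number 8 percentage points higher (within the scatter) from compound 1 to compound 2 and a number 12 percentage points higher (beyond the scatter) from compound 3 to compound 4, 4 percentage points apart, within the scatter of two such steps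

The compounds shown leave open what other groups at this place would do, for instance a hydroxyl, an ethoxy or a dimethylamino group, since only chloro and methoxy appear there. They also leave open whether the same swap would hold with a carboxylic acid in place of the hydroxycarbamoyl group, or with a longer chain joining the two ring parts of the molecule.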